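A pyridin-3-yl group in place of a methyl

This account rests on a few compounds, and the source may have more. Where it says the series, first, only, none or still open, it means among the compounds named here.

Of the compounds shown here, two have been measured in a functional assay on HUVEC cells (Homo sapiens) for inhibition, using NADPH, with a stated time of 2 h; a higher number here means a weaker inhibitor, a lower number a stronger inhibitor. Compound 1 (`Cc1ccc2[nH]c(COc3cccc(OCC4CCOCC4)c3)c(C)c(=O)c2c1`) gives 38 nM, and compound 2 (`O=c1c(Cl)c(COc2cccc(OCC3CCOCC3)c2)[nH]c2ccccc12`) gives 12 nM. Compound 1 therefore has the higher number of the two, which marks it as the weaker inhibitor, and the gap between them lies beyond the usual scatter. The two compounds differ in more than one place, so their values do not isolate the effect of any single change.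

Compound 3 (`Cc1c(COc2cccc(OCC3CCOCC3)c2)[nH]c2ccc(-c3cccnc3)cc2c1=O`) has yet to be measured. It departs from compound 1 in one place: pyridin-3-yl in place of methyl on an aromatic carbon. In words, pyridin-3-yl stands in place of methyl on an aromatic carbon. For the measured compounds named here, no measured pair tests a change at this place, so the expectation is loose. No step beyond the scatter is expected in this assay, in either direction. The estimated step is a 1.1-fold higher number from compound 1 to compound 3 (0.02 log units; within the scatter). Compound 3 is expected to give about 40 nM, with an estimated range from 10 nM to 160 nM.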

Compound 3, half-maximal inhibitory concentration: > 10000 nM
Compound 3: a limit, no number (the forecaster's own chance of this, stated with the estimate: 3%); middle value at least 250-fold (2.39 log units) from the limit.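

In this assay, the place on an aromatic carbon of the shared core proves highly sensitive to what stands there, which the first two compounds could not show because they differ in more than one place. Exchanging methyl for pyridin-3-yl gives an at least 260-fold higher number from compound 1 to compound 3 (2.42 log units; beyond the scatter), so this single change takes the compound from a clear value to the edge of what the assay reports. For compound 3 the reading of > 10000 nM is a limit and not a number: the limit of > 10000 nM in this assay, at which 1 of the 3 values shown sits.

The compounds shown do not tell whether the loss goes with the added ring as a whole or with its nitrogen, and a plain phenyl ring, or a smaller group such as fluorine or methoxy, would be needed to see whether activity stays close to that of compound 1, with 38 nM. Also open, on these data alone, is whether the same exchange would have a similar effect on the core of compound 2, which carries a chlorine and lacks both methyl groups of compound 1.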